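This account rests on a few compounds, and the source may have more. Where it says the series, first, only, none or still open, it means among the compounds named here.

In an ADME assay on MRC5 cells (Homo sapiens) for cytotoxicity, read by neutral red uptake (on this read-out higher numbers stand for lower toxicity in this test and lower numbers for higher toxicity in this test), three compounds have been tested so far: compound 1 (`O=c1[nH]c(SCc2ccccc2)nc2ccccc12`), compound 2 (`O=c1[nH]c(SCc2cc([N+](=O)[O-])cc([N+](=O)[O-])c2)nc2ccc(Cl)cc12`) and compound 3 (`O=c1[nH]c(SCc2cc([N+](=O)[O-])cc([N+](=O)[O-])c2)nc2cc(Cl)ccc12`). Compound 1 gives > 64000 nM as a limit of the assay, not a number. Compound 2 gives > 64000 nM as a limit too. Compound 3 gives > 64000 nM as a limit as well. Compound 2 therefore has no exact value and no rank among the three. Its place is the limit of > 64000 nM in this assay, at which 3 of the 3 values shown sit, and nothing finer can be said.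

The next compound is compound 4 (`CN(C)c1ccc2nc(SCc3cc([N+](=O)[O-])cc([N+](=O)[O-])c3)[nH]c(=O)c2c1`), which differs from compound 2 in one place: dimethylamino in place of chloro on an aromatic carbon. Among the compounds with values here, no two measured compounds differ in a single place, so no measured step shows what such a swap does in this assay. Within the data shown here, the only guide is the limit of compound 2 at > 64000 nM and that guide is not an exact number. No change beyond the usual scatter is expected, in either direction. The expected size of a number no higher from compound 2 to compound 4 (the limit leaves the size open) is correspondingly small. Compound 4 is estimated at 64000 nM with an expected range from 25000 nM to 100000 nM and it may well return only a limit again.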

Compound 4, half-maximal cytotoxic concentration: 14000 nM
For compound 4 the middle estimate is 4.6-fold (0.66 log units) above the measured one; measured number outside the range, below it.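

In this assay, putting dimethylamino in place of chloro on this aromatic carbon gives an at least 4.5-fold lower number from compound 2 to compound 4 (0.66 log units; beyond the scatter), and a lower number here stands for higher toxicity in this test. This is the first sign among the compounds shown that the group at this position can move the read-out beyond the usual scatter, since until now every compound sat at the same limit and nothing separated them. The step can only be given as a minimum and the real change may be larger, because compound 2 has a limit and not an exact number: the limit of > 64000 nM in this assay, at which 3 of the 4 values shown sit.

With a single swap at this position, the compounds shown cannot tell whether the nitrogen of dimethylamino matters or whether any larger group would do the same, and a plain amino group, a methoxy group or a longer diethylamino chain on the same carbon would help to separate these two readings. From the compounds shown here alone, it also stays open whether dimethylamino would lower the number in the same way at the place that holds chloro in compound 3, or on a core without the two nitro groups.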